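The compounds below may be only part of what the source reports. "The series", "measured", "known", "first", "only" and "open" are said of these compounds alone.

Measured in a functional assay on MCF7 cells (Homo sapiens) for antiproliferative activity, read by colorimetric assay and sulforhodamine B assay, with a stated time of 3 days; a lower number here means a stronger inhibitor, a higher number a weaker inhibitor:
Compound 1 `Brc1ncnc2c1ncn2CC1COc2ccccc2S1`: 6180 nM
Compound 2 `Clc1ncnc2c1ncn2CC1CSc2ccccc2O1`: 9240 nM

Compound 2 and compound 1 lie within the scatter of each other, so the numbers do not rank them. Compound 3 `Brc1ncnc2c1ncn2CC1CSc2ccccc2O1` has bromo in place of chloro on an aromatic carbon of compound 2 (bromo in place of chloro on an aromatic carbon). No two measured compounds differ in one place only, so the size of this step has not been shown directly. Compound 1 also carries bromo and gives 6180 nM, so no shift beyond the scatter is expected in this assay. The estimated step is a 1.2-fold lower number from compound 2 to compound 3 (0.09 log units; within the scatter). The expected value for compound 3 is 7500 nM, with an estimated range of 3500 nM to 15000 nM.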

Compound 3, half-maximal inhibitory concentration: 4870 nM
Estimate against measurement, compound 3: 1.5-fold (0.19 log units) above; the range from low to high includes it.
By their numbers in this assay, from the lowest: compounds 3, 1 and 2 (each within the scatter of the next).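

For the compounds shown here, this pair gives the first direct reading of bromo in place of chloro on this aromatic carbon, next to the ring nitrogen: in this assay the change gives a 1.9-fold lower number from compound 2 to compound 3 (0.28 log units; within the scatter) and so stays small. With these two halogens, then, the number at this position does not separate the compounds. No measurement on hand accounts for the size of this step.

Going by these compounds, whether an amine, a methoxy group or a plain hydrogen on the same carbon would give a step beyond the scatter remains open.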